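Taking the nitro group off compound 3

The source may hold more compounds than are shown below. What is called first, only, known or untested is meant among the compounds shown, and "the series" means these compounds.

In a functional assay on K562 cells (Homo sapiens) for antiproliferative activity, read by MTT assay, with a stated time of 5 days (on this read-out lower numbers stand for stronger inhibition and higher numbers for weaker inhibition), compound 1 (`COc1ccc(C=C(C(=O)c2cc(OC)c(OC)c(OC)c2)c2ccccc2O)cc1`) gives 240000 nM and compound 3 (`COc1ccc(C=C(C(=O)c2cc(OC)c(OC)c(OC)c2)c2ccc(C)cc2)cc1[N+](=O)[O-]`) gives 2430000 nM, the higher of the two numbers, with a gap beyond the scatter. Compound 2 (`COc1ccc(C=C(C(=O)c2cc(OC)c(OC)c(OC)c2)c2ccccc2)cc1[N+](=O)[O-]`) reads > 10000000 nM, which is a limit of the assay. Among the compounds with values here, the only measured step, an at least 4.1-fold lower number from compound 2 to compound 3 (0.61 log units; beyond the scatter), is methyl in place of hydrogen on an aromatic carbon, a different change, so it bears little on compound 4 (`COc1ccc(C=C(C(=O)c2cc(OC)c(OC)c(OC)c2)c2ccc(C)cc2)cc1`). That compound differs from compound 3 by hydrogen in place of nitro on an aromatic carbon, turning 4-methoxy-3-nitrophenyl into 4-methoxyphenyl. Within the data shown here, no measured step covers this change. Compound 1 also carries 4-methoxyphenyl, and its 240000 nM tentatively suggests a lower number. The expected change is a 2.4-fold lower number from compound 3 to compound 4 (0.39 log units; beyond the scatter). For compound 4 the estimated value is 1000000 nM, with an expected range from 150000 nM to 5000000 nM.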

Compound 4, half-maximal inhibitory concentration: 760000 nM
Compound 4: the middle estimate sits 1.3-fold (0.12 log units) above what was measured, within the range that was stated.
By their numbers in this assay, from the lowest: compound 1; then compound 4; then compound 3. At a limit, above all of these: compound 2.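

Hydrogen in place of nitro, on the aromatic carbon ortho to a methoxy group, gives a 3.2-fold lower number from compound 3 to compound 4 (0.50 log units; beyond the scatter), the first reading of any change at this position. With 4-methoxyphenyl held in both, 4-methylphenyl in place of 2-hydroxyphenyl gives a 3.2-fold higher number from compound 1 to compound 4 (0.50 log units; beyond the scatter), so the group on the chain carbon also moves the number. Nothing given here accounts for either step.

On these data alone, how an amine or a fluorine atom at this position would read stays open. So does whether the nitro step would hold with 2-hydroxyphenyl in place of 4-methylphenyl.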